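Ester chain length and rat 5-lipoxygenase inhibition

The source may report more compounds than this note shows. Statements on the series, on what has been measured and on what is new or still open speak of the compounds shown alone.

Measured compounds:
compound 1 `COC(=O)CCC(=O)Nc1cccc(OCc2ccc3ccccc3n2)c1`: 28000 nM
compound 2 `COC(=O)C(=O)Nc1cccc(OCc2ccc3ccccc3n2)c1`: 5300 nM

Within the data shown here, in an assay on isolated protein for inhibition of Polyunsaturated fatty acid 5-lipoxygenase (Rattus norvegicus) (a higher number here means a weaker inhibitor, a lower number a stronger inhibitor), compound 2 holds the lowest of the two numbers; compound 1 is its only neighbour, reached by a step of a 5.3-fold lower number from compound 1 to compound 2 (0.72 log units; beyond the scatter). Compound 3 `CCOC(=O)CCC(=O)Nc1cccc(OCc2ccc3ccccc3n2)c1` differs from compound 2 by 2-(ethoxycarbonyl)ethyl in place of methoxycarbonyl on a carbonyl carbon. This change largely undoes the shortening seen going from compound 1 to compound 2, so a weakening step is expected, in the order of a 5.3-fold lower number from compound 1 to compound 2 (0.72 log units; beyond the scatter) reversed. Compound 3 is therefore estimated at 25000 nM in this assay, with a range of 8000 nM to 70000 nM, corresponding to an expected step of a 4.7-fold higher number from compound 2 to compound 3 (0.67 log units; beyond the scatter).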

Compound 3, half-maximal inhibitory concentration: 12600 nM
Compound 3: middle estimate off by 2.0-fold (0.30 log units), on the high side, within the range that was stated.
By their numbers in this assay, from the lowest: compound 2; then compound 3; then compound 1.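

In this assay, methyl in place of hydrogen on the saturated chain carbon bound to the ester oxygen gives a 2.2-fold lower number from compound 1 to compound 3 (0.35 log units; beyond the scatter), so the ester end of the chain moves the number as well as the chain length. Methoxycarbonyl still keeps the lowest number, with a 2.4-fold higher number from compound 2 to compound 3 (0.38 log units; beyond the scatter) on going to 2-(ethoxycarbonyl)ethyl, a change that alters both chain and ester end. Nothing available bears on the reason for either step.

The compounds shown leave open whether an ethyl ester on the shorter chain would give a similar step. Going by these compounds, how a carboxylic acid in place of the ester would read in this assay also stays open.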